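This account rests on a few compounds, and the source may have more. Where it says the series, first, only, none or still open, it means among the compounds named here.

The compounds below were examined in a functional assay on Huh-7 cells (Homo sapiens) for cytotoxicity, read by MTT assay, with a stated time of 3 days; on this read-out lower numbers stand for higher toxicity in this test and higher numbers for lower toxicity in this test. Compound 1, `OC[C@H]1O[C@@H](n2cnc3c(CS)ncnc32)C[C@@H]1O`, gives 41000 nM in this assay. Compound 3, `CC(=O)N(Cc1ccccc1)Cc1ncnc2c1ncn2[C@@H]1O[C@H](CO)[C@@H](O)[C@H]1O`, reaches only a limit of the test, > 100000 nM. Compound 2, `OC[C@H]1O[C@@H](n2cnc3c(COc4ccccn4)ncnc32)[C@H](O)[C@@H]1O`, likewise reaches only a limit in this assay, > 250000 nM. So compound 2 stands with no number of its own, and one further value among the three is also a limit: one sits at the limit of > 100000 nM in this assay, at which 1 of the 3 values shown sits, and one at the limit of > 250000 nM in this assay, at which 1 of the 3 values shown sits.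

Compound 4, `O=c1ccccn1Cc1ncnc2c1ncn2[C@@H]1O[C@H](CO)[C@@H](O)[C@H]1O`, has the same atoms as compound 2, joined differently: a group of 7 heavy atoms (5 carbon, 1 nitrogen, 1 oxygen; one six-membered aromatic ring with 1 hetero atom) in place of a group of 7 heavy atoms (5 carbon, 1 nitrogen, 1 oxygen; one six-membered aromatic ring with 1 hetero atom), on a saturated chain carbon bound to an aromatic carbon. Going by the values given here, no step between measured compounds is available here, so the expectation for compound 4 rests on compound 2 alone, whose result is a limit, > 250000 nM. The step expected from compound 2 to compound 4 is a number no higher from compound 2 to compound 4 (the limit leaves the size open), that is, none beyond the usual scatter, and the outcome for compound 4 is expected most often to be a limit again. Compound 4 is estimated to give 250000 nM in this assay, with a range from 60000 nM to 600000 nM.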

Compound 4, half-maximal cytotoxic concentration: > 100000 nM
Compound 4: a limit, no number (the forecaster's own chance of this, stated with the estimate: 70%); the middle value lies beyond the limit too.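

Compound 2 and compound 4 both end at a limit of the test rather than at a number, so no step can be read between them. The compounds shown leave open whether replacing the (pyridin-2-yl)oxy group with the group in compound 4 changes toxicity in this test at all.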